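The source may report more compounds than this note shows. Statements on the series, on what has been measured and on what is new or still open speak of the compounds shown alone.

Compound 1, `CC(C)(C)OC(=O)Nc1ncc(C(Oc2ccc(Br)cc2)c2ccc(Cl)cc2)s1`: in an ADME assay on HepG2 2.2.15 cells (Homo sapiens) for cytotoxicity (on this read-out higher numbers stand for lower toxicity in this test and lower numbers for higher toxicity in this test), compound 1 gives > 50000 nM, which is a limit of the assay and not a number.
Compound 2, `Cc1cc(Br)cc(OC(c2ccc(Cl)cc2)c2cnc(NC(=O)OC(C)(C)C)s2)c1`: compound 2 gives > 50000 nM, again a limit rather than a number.
Compound 3, `CC(C)(C)OC(=O)Nc1ncc(C(Oc2ccc3cc(Br)ccc3c2)c2ccc(Cl)cc2)s1`: compound 3 gives > 50000 nM, once more a limit rather than a number.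

So compound 3 stands where every measured compound stands, at the upper edge of what this test can report; the limit of > 50000 nM in this assay, at which 3 of the 3 values shown sit, describes that shared position. Because of this, the three steps among the measured compounds cannot be read: a step that the two limits leave unreadable from compound 1 to compound 2, a step that the two limits leave unreadable from compound 1 to compound 3 and a step that the two limits leave unreadable from compound 2 to compound 3 all vary only the aryl group on the ether oxygen and all leave the read-out at the limit.

Compound 4, `O=C(Nc1ncc(C(Oc2ccc3cc(Br)ccc3c2)c2ccc(Cl)cc2)s1)C1CCOCC1`, is not yet measured. It differs from compound 3 at the carbonyl carbon, where (oxan-4-yl in place of tert-butoxy on a carbonyl carbon); the tert-butoxy group leaves and an oxan-4-yl group enters. Among the compounds with values here, none of the measured steps touches this position, so they give no direct guidance on its size, only a background in which nothing has moved the value off the limit.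

With that background, the step expected in this assay is a step that the limit leaves unreadable from compound 3 to compound 4, that is, no change beyond the scatter. The estimate for compound 4 is therefore 60000 nM, within a range from 20000 nM to 200000 nM, most likely reported again only as a limit.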

Compound 4, half-maximal cytotoxic concentration: "not toxic" (no number reported)
No number was reported for compound 4; there is nothing to compare the estimate with.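

In this assay compound 4 is recorded only as "not toxic", without a number. Within the data shown here, compound 3 gives > 50000 nM as a limit and not a number, so no step between compound 3 and compound 4 can be read. The compounds shown leave open whether changing the aryl group on the ether oxygen, or oxan-4-yl in place of tert-butoxy, shifts the half-maximal cytotoxic concentration at all.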